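The source may report more compounds than this note shows. Statements on the series, on what has been measured and on what is new or still open speak of the compounds shown alone.

Of the compounds shown here, three sharing one core have been measured in a functional assay on HeLa cells (Homo sapiens) for inhibition, read by sulforhodamine B assay; on this read-out higher numbers stand for weaker inhibition and lower numbers for stronger inhibition. Compound 2 `O=C1C=C(Nc2ccccc2)C(=O)c2c1nc1n2[C@H]2OC[C@@H](O)[C@H]2OC1` carries a plain phenyl on the amine nitrogen and gives 5620 nM. Compound 3 `Cc1ccc(NC2=CC(=O)c3c(nc4n3[C@H]3OC[C@@H](O)[C@H]3OC4)C2=O)cc1` carries a 4-methylphenyl on that nitrogen and gives 6590 nM; the two numbers sit within the usual scatter of each other, so neither can be called the stronger. Compound 1 `COc1cccc(NC2=CC(=O)c3c(nc4n3[C@H]3OC[C@@H](O)[C@H]3OC4)C2=O)c1`, with a 3-methoxyphenyl, gives only a limit of the assay, > 8000 nM. For the measured compounds named here, the one step counted between neighbours, an at least 1.2-fold lower number from compound 1 to compound 3 (0.08 log units; that floor lies within the scatter), is itself only a floor because one of its ends is the limit of > 8000 nM in this assay, at which 1 of the 3 values shown sits. Compound 4 `CCOc1ccccc1NC1=CC(=O)c2nc3n(c2C1=O)[C@H]1OC[C@@H](O)[C@H]1OC3` differs from compound 2 in one place: ethoxy in place of hydrogen on an aromatic carbon. Going by the values given here, no measured step bears directly on an ethoxy at this place; the methyl of compound 3 left the number where compound 2 stands, while the methoxy of compound 1 ended at a limit. The change is therefore expected to bring only a modest shift in this assay, a 1.2-fold higher number from compound 2 to compound 4 (0.06 log units; within the scatter), with a real chance that the assay again reports a limit rather than a number. Compound 4 is estimated at 6500 nM, within a range from 2500 nM to 16000 nM.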

Compound 4, half-maximal inhibitory concentration: 6040 nM
Compound 4: middle estimate off by 1.1-fold (0.03 log units), on the high side; measured number inside the range.
By their numbers in this assay, from the lowest: compounds 2, 4 and 3 (each within the scatter of the next). At a limit, above all of these: compound 1.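

The step to a 2-ethoxyphenyl on the amine nitrogen is a 1.1-fold higher number from compound 2 to compound 4 (0.03 log units; within the scatter), so in this assay an ethoxy on this aromatic carbon, ortho to a large group, makes no difference that can be told from the plain phenyl. Compound 1, the only other compound shown with an oxygen-linked group on this phenyl, gives only a limit, > 8000 nM. Compound 4 supplies what that limit could not, an actual number for a phenyl carrying such a group, and the set still holds just one limit: the limit of > 8000 nM in this assay, at which 1 of the 4 values shown sits.

Compounds 2, 4 and 3 each sit within the scatter of the next, so the compounds shown do not tell whether any change on this phenyl can move the number by a real amount, or whether an ethoxy would read the same on another carbon of the ring. As far as these compounds go, how an amine, a carboxylic acid or a longer chain on this carbon would read in this assay remains open.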